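Moving from a pyrazole arm to a lactam ring

The source may hold more compounds than are shown below. What is called first, only, known or untested is meant among the compounds shown, and "the series" means these compounds.

Of the compounds shown here, two built on the same core have been measured in an assay on cells for positive allosteric modulation of Cystic fibrosis transmembrane conductance regulator variant F508del (Homo sapiens), with stated times of 10 min and 7 s, in the presence of a further agent that is not named here; on this read-out lower numbers stand for an effect already at smaller amounts and higher numbers for an effect only at larger amounts of compound. Compound 1 `CC1(C)Cc2c(sc(NC(=O)c3ccn[nH]3)c2C(N)=O)C(C)(C)O1` gives 3 nM. Compound 2 `CC1(C)Cc2c(sc(NC(=O)Cc3ccn[nH]3)c2C(N)=O)C(C)(C)O1`, which carries the (1H-pyrazol-5-yl)methyl group on the carbonyl carbon instead of 1H-pyrazol-5-yl, gives 136 nM. That change produced a 45-fold higher number from compound 1 to compound 2 (1.66 log units; beyond the scatter), so compound 2 stands at the higher of the two numbers, with compound 1 clearly separated from it.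

Compound 3 `CC1(C)Cc2c(sc(NC(=O)C3CCNC3=O)c2C(N)=O)C(C)(C)O1` has not yet been measured. It differs from compound 2 by 2-oxopyrrolidin-3-yl in place of (1H-pyrazol-5-yl)methyl on a carbonyl carbon. Among the compounds with values here, the only step seen so far concerns the insertion of a single carbon between the carbonyl and the aromatic ring, which was a large step; no measured pair shows an aromatic ring giving way to a non-aromatic one at this position, so that side of the change has no comparison to rest on. An estimate therefore leans on the value of compound 2 and allows a wide range. Compound 3 is expected to give about 100 nM in this assay, within 15 nM to 700 nM, meaning an expected step of a 1.4-fold lower number from compound 2 to compound 3 (0.13 log units; within the scatter).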

Compound 3, half-maximal effective concentration: 101 nM
Compound 3: the middle estimate sits 1.0-fold (0.00 log units) below what was measured; the measured number falls inside the stated range.
By their numbers in this assay, from the lowest: compound 1; then compounds 3 and 2 (each within the scatter of the next).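

In this assay the aromatic ring of the arm on this carbonyl carbon proves dispensable at the level of compound 2, since putting 2-oxopyrrolidin-3-yl in place of (1H-pyrazol-5-yl)methyl gives a 1.3-fold lower number from compound 2 to compound 3 (0.13 log units; within the scatter) and so leaves the two compounds indistinguishable. Measured against 1H-pyrazol-5-yl, the same non-aromatic ring gives a 34-fold higher number from compound 1 to compound 3 (1.53 log units; beyond the scatter) and thus falls short of compound 1 much as the other arm does with a 45-fold higher number from compound 1 to compound 2 (1.66 log units; beyond the scatter) on record, which leaves compound 1 alone at the low end among these three. The data offer no independent measurement that could explain why these groups read as they do and so the comparison stays purely descriptive.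

The compounds shown leave open whether the low number of compound 1 needs the pyrazole itself or would also appear with another aromatic ring on the carbonyl carbon, such as a phenyl or an imidazole ring. They also leave open how an open-chain group at this place would read, for example a simple amine or a carboxylic acid on a longer chain.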